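The compounds below may be only part of what the source reports. "The series", "measured", "known", "first", "only" and "open" are said of these compounds alone.

Measured compounds in an assay on MDA-MB-231 cells for binding affinity to C-X-C chemokine receptor type 4 (Homo sapiens), read by immunofluorescence and microscopy, with stated times of 10 min and 30 min; a lower number here means that less compound is needed, a higher number that more compound is needed for the effect:
- compound 1 `COc1cccc(C(=O)NCc2ccc(CNS(=O)(=O)c3ccc(C)cc3)cc2)c1` gives 10 nM
- compound 2 `Cc1ccc(S(=O)(=O)NCc2ccc(CNC(=O)c3ccc(Cl)cc3)cc2)cc1` gives 10 nM
- compound 3 `COc1ccccc1C(=O)NCc1ccc(CNS(=O)(=O)c2ccc(C)cc2)cc1` gives 100 nM

Compound 3 holds the highest number of the three. From compound 1 the step is a 10-fold higher number from compound 1 to compound 3 (1.00 log units; beyond the scatter), and from compound 2 it is a 10-fold higher number from compound 2 to compound 3 (1.00 log units; beyond the scatter), while compound 1 and compound 2 differ by no change at the digits printed from compound 1 to compound 2 (within the scatter). Both measured routes to compound 3 therefore end in a higher number, and the two groups that give the lower numbers sit on the carbonyl carbon without a group on the ring position that carries the methoxy in compound 3.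

The next compound, compound 4 `Cc1ccc(S(=O)(=O)NCc2ccc(CNC(=O)c3c(Cl)cc(Cl)cc3Cl)cc2)cc1`, changes compound 3 by 2,4,6-trichlorophenyl in place of 2-methoxyphenyl on a carbonyl carbon. Compound 2 bears most directly on it: its 4-chlorophenyl gave a low number, and the step of a 10-fold higher number from compound 2 to compound 3 (1.00 log units; beyond the scatter) shows that the 2-methoxyphenyl is what raises the number. Within the data shown here, compound 4 removes that methoxy but brings chlorines onto the same ring in three places, two of them at positions for which no measured compound gives guidance. The expectation is a lower number than compound 3, and the expected step is a 3.3-fold lower number from compound 3 to compound 4 (0.52 log units; beyond the scatter). The estimate for compound 4 in this assay is 30 nM, within a range of 5 nM to 300 nM.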

Compound 4, effective concentration (reported as EC, without a stated level of effect): 10 nM
Beside the measured number, compound 4's estimate is 3.0-fold (0.48 log units) above it; the measured number falls inside the stated range.
By their numbers in this assay, from the lowest: compounds 1, 2 and 4 (each within the scatter of the next); then compound 3.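

In this assay, 2,4,6-trichlorophenyl in place of 2-methoxyphenyl on the carbonyl carbon gives a 10-fold lower number from compound 3 to compound 4 (1.00 log units; beyond the scatter) even though the new ring also carries a group at the 2 position, so a group there does not by itself go with the higher number. Against the 4-chlorophenyl the same ring gives no change at the digits printed from compound 2 to compound 4 (within the scatter) and against the 3-methoxyphenyl it gives no change at the digits printed from compound 1 to compound 4 (within the scatter) in this series, leaving the 2-methoxyphenyl of compound 3 as the only group shown here that stands apart. Nothing measured here accounts for that difference.

Open, going by these compounds, is whether the higher number belongs to the methoxy itself, which a 2-chlorophenyl or 2-methylphenyl on the same carbonyl carbon would test. Also open, on these data alone, is how this position responds to a ring carrying an amine or a carboxylic acid, or to a saturated group such as cyclohexyl.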